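A few compounds are considered here, and "the series" means these few. Any claim that something is new, unique, unknown or untested is made for them only; others in the source may bear on it.

The measured compounds: compound 1 `COc1cc(-c2cc(SC)nc(Nc3nc(N4CCN(C)CC4)nc(N4CCN(C)CC4)n3)n2)cc(OC)c1OC` with 16.5 ug/mL, compound 2 `CCCNc1nc(NCCC)nc(Nc2nc(SC)cc(-c3cc(OC)c(OC)c(OC)c3)n2)n1` with 1.46 ug/mL, and compound 3 `COc1ccc(-c2cc(SC)nc(Nc3nc(N4CCN(C)CC4)nc(N4CCN(C)CC4)n3)n2)cc1OC` with 36.2 ug/mL.

In an ADME assay on J774.A1 cells (Mus musculus) for cytotoxicity, read by MTT assay, with a stated time of 72 h (on this read-out lower numbers stand for higher toxicity in this test and higher numbers for lower toxicity in this test), compound 2 gives the lowest of the three numbers. The difference between the core of compound 2 and the core of compound 1 is not broken down here. Compound 3 differs from compound 1 by hydrogen in place of methoxy on an aromatic carbon, and that change gave a 2.2-fold higher number from compound 1 to compound 3 (0.34 log units; beyond the scatter). Compound 4 `CCCNc1nc(NCCC)nc(Nc2nc(SC)cc(-c3ccc(OC)c(OC)c3)n2)n1` is not yet measured; it differs from compound 2 by hydrogen in place of methoxy on an aromatic carbon, the same change made once more. Going by the values given here, the step from compound 2 to compound 4 is expected to be of similar size, a 2.2-fold higher number from compound 2 to compound 4 (0.34 log units; beyond the scatter), because the single measured example of this change showed a 2.2-fold higher number from compound 1 to compound 3 (0.34 log units; beyond the scatter). Compound 4 is therefore estimated at 3.2 ug/mL in this assay, most likely between 1.3 ug/mL and 7.5 ug/mL.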

Compound 4, half-maximal cytotoxic concentration: 14.3 ug/mL
Estimate against measurement, compound 4: 4.5-fold (0.65 log units) below, and the stated range ends below it.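

In this assay, hydrogen in place of methoxy on an aromatic carbon gave a 9.8-fold higher number from compound 2 to compound 4 (0.99 log units; beyond the scatter). The direction held on both cores, but the size did not carry over: the same change on two cores in this assay, a 2.2-fold higher number (0.34 log units; beyond the scatter) from compound 1 to compound 3 and a 9.8-fold higher number (0.99 log units; beyond the scatter) from compound 2 to compound 4, 4.5-fold (0.65 log units) apart, beyond the scatter of two such steps. These two pairs show that a step measured on one core does not fix its size on another in this series, but they do not show what sets that size or whether the direction would hold on further cores.

The compounds shown leave open how the step would behave on a core bearing chains longer than propyl. They also leave open what a hydroxyl group or a fluorine atom would do in place of the methoxy group.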